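Isobutyl Replaces Isopropyl on a Piperidine Nitrogen

The source may report more compounds than this note shows. Statements on the series, on what has been measured and on what is new or still open speak of the compounds shown alone.

Of the compounds shown here, three sharing one core have been measured in an assay on HEK293 cells for inhibition of acid ceramidase (Homo sapiens), read by fluorescence, with stated times of 10 min and 3 h; on this read-out lower numbers stand for stronger inhibition and higher numbers for weaker inhibition. Compound 1 `CC(C)CNC(=O)n1c(=O)oc2ccc(C3CCN(C)CC3)cc21` gives 295 nM and compound 3 `CC(C)CNC(=O)n1c(=O)oc2c(C3CCN(C)CC3)cccc21` gives 535 nM. Compound 2 `CC(C)N1CCC(c2ccc3c(c2)oc(=O)n3C(=O)NCCCCc2ccccc2)CC1` gives 94 nM, the lowest of the three numbers and thus the strongest inhibitor among them, as both other values lie above it by more than the usual scatter. Compound 4 `CC(C)CN1CCC(c2ccc3c(c2)oc(=O)n3C(=O)NCCCCc2ccccc2)CC1` has not yet been measured. It differs from compound 2 in one place: isobutyl in place of isopropyl on an amine nitrogen in a ring. Among the compounds with values here, no measured pair shows what such a change does, so the expectation rests on compound 2 alone. The step of a 1.1-fold lower number from compound 2 to compound 4 (0.04 log units; within the scatter) is expected to stay within the usual scatter, with no clear direction. Compound 4 is therefore estimated at 85 nM, with a range from 35 nM to 210 nM.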

Compound 4, half-maximal inhibitory concentration: 120 nM
The estimate for compound 4 lay 1.4-fold (0.15 log units) below the measured number, and the stated range covers the measured number.
By their numbers in this assay, from the lowest: compounds 2 and 4 (each within the scatter of the next); then compounds 1 and 3 (each within the scatter of the next).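

In this assay, within the data shown here, isobutyl in place of isopropyl on the amine nitrogen in the ring gives a 1.3-fold higher number from compound 2 to compound 4 (0.11 log units; within the scatter), the first direct reading of this change. At this position, the two groups therefore cannot be told apart by this assay, at least with the rest of compound 2 held fixed. Nothing measured here offers an explanation for this result.

From the compounds shown here alone, whether a longer chain, a cyclohexyl ring or a carboxylic acid on this nitrogen would keep the number in the same range remains open. The same question holds for the swap itself on a different core or with a different group on the shared urea-like side chain.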